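Demethylation of the amine in a tetrahydronaphthalene sulfonamide series

This account rests on a few compounds, and the source may have more. Where it says the series, first, only, none or still open, it means among the compounds named here.

Two compounds of the series carry a number in an assay on isolated protein for binding affinity to Alpha-1A adrenergic receptor (Rattus norvegicus), read by radioligand binding; on this read-out lower numbers stand for stronger inhibition and higher numbers for weaker inhibition. Compound 1 `CCS(=O)(=O)Nc1cc(C2CCCCC2)cc2c1CCCC2c1c[nH]cn1` gives 269 nM. Compound 2 `CCS(=O)(=O)Nc1cccc2c1CCCC2CNC` gives 1380 nM, the highest of the two numbers; the gap between compound 1 and compound 2 lies beyond the scatter of repeated measurements, so compound 2 is the weaker of the pair in this assay. Compound 3 `CCS(=O)(=O)Nc1cccc2c1CCCC2CN` has not been measured. It differs from compound 2 in one place: hydrogen in place of methyl on an amine nitrogen. Among the compounds with values here, no measured pair shows this kind of change, so nothing in the data fixes its size or direction. The step from compound 2 to compound 3 is therefore expected to be small, a 1.3-fold higher number from compound 2 to compound 3 (0.12 log units; within the scatter), with no clear direction beyond the scatter. Compound 3 is estimated at 1800 nM, with a range of 600 nM to 5500 nM in this assay.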

Compound 3, inhibition constant: 794 nM
Compound 3: middle estimate off by 2.3-fold (0.36 log units), on the high side, and the stated range covers the measured number.
By their numbers in this assay, from the lowest: compound 1; then compounds 3 and 2 (each within the scatter of the next).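

On an amine nitrogen whose other neighbour is a saturated chain carbon, hydrogen in place of methyl now has its first reading in the series: in this assay the step is a 1.7-fold lower number from compound 2 to compound 3 (0.24 log units; within the scatter), so methylamino to amino on this core does not shift the number beyond the scatter. The methyl group is therefore not required for compound 3 to keep a number within the scatter of compound 2. No measurement in hand explains the size of this step.

From the compounds shown here alone, whether an ethyl group or a second methyl group on this nitrogen, or a longer chain carrying the amine, would move the number beyond the scatter remains open. Compound 1 differs from compound 3 in more than one place, so it cannot settle what the amine contributes.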